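Working notes: the step from compound 3 to compound 4

The source may hold more compounds than are shown below. What is called first, only, known or untested is meant among the compounds shown, and "the series" means these compounds.

In a functional assay on HCT-116 cells (Homo sapiens) for antiproliferative activity, read by MTT assay, with a stated time of 24 h (a higher number here means a weaker inhibitor, a lower number a stronger inhibitor), compound 1 `COc1ccc(C(=O)/C=C/c2ccccn2)c2c1C=CC(C)(C)O2` gives 6630 nM and compound 2 `COc1ccc(C(=O)/C=C/c2ccc(Cl)c(Cl)c2)c2c1C=CC(C)(C)O2` gives 9440 nM on the shared core. Compound 3 `COc1ccc(C(=O)/C=C/c2ccccc2Cl)c2c1C=CC(C)(C)O2` gives > 10000 nM as its reading, which is a limit and not a number.

Compound 4 `COc1ccc(C(=O)/C=C/c2cc(Cl)ccc2O)c2c1C=CC(C)(C)O2` carries 5-chloro-2-hydroxyphenyl in place of 2-chlorophenyl on a double-bonded chain carbon bound to a double-bonded chain carbon here.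

All three measured steps change the group at that same place: a 1.4-fold higher number from compound 1 to compound 2 (0.15 log units; within the scatter), then an at least 1.5-fold higher number from compound 1 to compound 3 (0.17 log units; that floor lies within the scatter), and an at least 1.0-fold higher number from compound 2 to compound 3 (0.02 log units; that floor lies within the scatter) as well. From the compounds shown here alone, none of them introduces a hydrogen-bond donor, so the effect of that addition is untested. On these small steps, no change beyond the scatter is expected in this assay in either direction. Compound 2, also chlorinated, at 9440 nM serves as the anchor for this expectation. The estimated step is an at least 1.1-fold lower number from compound 3 to compound 4 (0.07 log units; that floor lies within the scatter) overall. Compound 4 is estimated at 8500 nM, with an expected range from 4000 nM to 16000 nM overall.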

Compound 4, half-maximal inhibitory concentration: 5240 nM
Beside the measured number, compound 4's estimate is 1.6-fold (0.21 log units) above it; the range from low to high includes it.
By their numbers in this assay, from the lowest: compounds 4, 1 and 2 (each within the scatter of the next). At a limit, above all of these: compound 3.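

In this assay, 5-chloro-2-hydroxyphenyl is the only group shown at this place that carries a hydrogen-bond donor, and its steps from the two compounds with numeric readings stay inside the scatter: a 1.3-fold lower number from compound 1 to compound 4 (0.10 log units; within the scatter) and a 1.8-fold lower number from compound 2 to compound 4 (0.26 log units; within the scatter). So the series now shows that a group with a hydrogen-bond donor at this place gives a number within the scatter of compounds 1 and 2, while the comparison with compound 3 gives only a floor, an at least 1.9-fold lower number from compound 3 to compound 4 (0.28 log units; that floor lies within the scatter), and the true size of that step cannot be read. The reading of compound 3 is a limit and not a number: the limit of > 10000 nM in this assay, at which 1 of the 4 values shown sits.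

Open, from the compounds shown here alone, is whether a plain 2-hydroxyphenyl, with no chlorine, would stay within the scatter of compound 4. Also open, going by these compounds, is whether a 2-aminophenyl or a phenyl bearing a carboxylic acid at this place would move the number beyond the scatter in either direction.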